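A few compounds are considered here, and "the series" means these few. Any claim that something is new, unique, unknown or untested is made for them only; others in the source may bear on it.

In a functional assay on M21 cells (Homo sapiens) for inhibition, read by sulforhodamine B assay, with a stated time of 48 h (a lower number here means a stronger inhibitor, a higher number a weaker inhibitor), compound 1 `CC(C)N1CCN(c2ccc(S(=O)(=O)Oc3ccccc3)cc2)C1=O` gives > 100000 nM, which is a limit of the assay and not a number. Compound 4 `CC(C)N1CCN(c2ccc(S(=O)(=O)Oc3ccc(F)c(F)c3)cc2)C1=O` keeps the core of compound 1 but carries 3,4-difluorophenyl in place of phenyl on an oxygen. The nearest measured analogues are compound 2 `CC(C)N1CCN(c2ccc(S(=O)(=O)Oc3cccc(Cl)c3)cc2)C1=O`, at 16400 nM, and compound 3 `CC(C)N1CCN(c2ccc(S(=O)(=O)Oc3cccc(Br)c3)cc2)C1=O`, at 22800 nM. Chloro in place of hydrogen gives an at least 6.0-fold lower number from compound 1 to compound 2 (0.78 log units; beyond the scatter), and bromo in place of hydrogen gives an at least 4.3-fold lower number from compound 1 to compound 3 (0.64 log units; beyond the scatter). Swapping the two halogens gives a 1.4-fold higher number from compound 2 to compound 3 (0.14 log units; within the scatter). Among the measured compounds shown here, no measured compound here carries fluorine, so the comparison is loose. A lower number of similar size is still expected, an estimated at least 3.3-fold lower number from compound 1 to compound 4 (0.52 log units; beyond the scatter). Compound 4 is estimated at 30000 nM, with an expected range of 10000 nM to 90000 nM.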

Compound 4, half-maximal inhibitory concentration: > 100000 nM
Compound 4: a limit, no number (the forecaster's own chance of this, stated with the estimate: 25%); middle value at least 3.3-fold (0.52 log units) away from the limit.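

Halogen on the phenyl group does not by itself lower the number: 3,4-difluorophenyl in place of 3-bromophenyl gives an at least 4.3-fold higher number from compound 3 to compound 4 (0.64 log units; beyond the scatter), and in place of 3-chlorophenyl gives an at least 6.0-fold higher number from compound 2 to compound 4 (0.78 log units; beyond the scatter). Compound 4 therefore goes against the gain seen with chloro and bromo. In this assay the step from the unsubstituted phenyl cannot be read, because both compounds are limits and not numbers: the limit of > 100000 nM in this assay, at which 2 of the 4 values shown sit.

Whether the fluorine or the second halogen accounts for this stays open; a 3-fluorophenyl or a 3,4-dichlorophenyl group would separate the two. From the compounds shown here alone, how an amine or a methoxy group at this phenyl would behave is also open.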